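Aryl ether acids: carboxyl position and the chloro substituent

The compounds below may be only part of what the source reports. "The series", "measured", "known", "first", "only" and "open" are said of these compounds alone.

Measured so far:
compound 1 `Cc1c(OCCCCOc2ccc(C(=O)O)cc2)ccc(C(=O)CC(C)C)c1C`: 19%
compound 2 `Cc1c(OCCCCOc2ccc(C(=O)O)c(Cl)c2)ccc(C(=O)CC(C)C)c1C`: 33.1%

In an assay on HEK293 cells for positive allosteric modulation of metabotropic glutamate receptor 2 (Rattus norvegicus), read by thallium flux, with a stated time of 2.5 min (a lower number here means a smaller maximal response, a higher number a larger maximal response), compound 1 gives 19%, and compound 2 gives 33.1%. Among the measured compounds shown here, compound 2 stands highest of the two numbers measured; its only neighbour is compound 1, and the step of a number 14.1 percentage points higher from compound 1 to compound 2 (beyond the scatter) lies beyond the scatter, so the two compounds are genuinely apart in this assay.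

Compound 3 `Cc1c(OCCCCOc2ccccc2C(=O)O)ccc(C(=O)CC(C)C)c1C` is not yet measured. Its structure differs from compound 2 in one place: 2-carboxyphenyl in place of 4-carboxy-3-chlorophenyl on an oxygen on a saturated carbon. The change therefore does two things at once: the chlorine that entered between compound 1 and compound 2 leaves again, and the carboxy group stands as 2-carboxyphenyl instead of 4-carboxy-3-chlorophenyl.

For the measured compounds named here, only one measured step bears on this. The step of a number 14.1 percentage points higher from compound 1 to compound 2 (beyond the scatter) shows what the chloro on the aromatic carbon brought, and compound 3 lacks it, so a downward step of about that size is expected. Going by the values given here, no measured pair shows what moving the carboxy does, so the range must be wide. The step is expected to be a number 13.1 percentage points lower from compound 2 to compound 3 (beyond the scatter).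

Compound 3 is estimated at 20%, with a range from 5% to 40%.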

Compound 3, largest response reached (reported as percent of maximum), in percent of the reference or control that the assay uses: 76.2%
Estimate against measurement, compound 3: 56.2 percentage points below; measured number outside the range, above it.
By their numbers in this assay, from the lowest: compound 1; then compound 2; then compound 3.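

In this assay, 2-carboxyphenyl in place of 4-carboxyphenyl gives a number 57.2 percentage points higher from compound 1 to compound 3 (beyond the scatter); these two structures differ in that one place only, so the placement of the carboxy group on the phenyl ring clearly matters for the maximal response. The chloro is not needed for a high response among these three compounds: with it gone, the change still gives a number 43.1 percentage points higher from compound 2 to compound 3 (beyond the scatter), and the earlier chloro step, a number 14.1 percentage points higher from compound 1 to compound 2 (beyond the scatter), is the smaller effect on the 4-carboxyphenyl series. Nothing available gives a reason for the effect of moving the carboxy group.

The compounds shown leave open whether a chloro on 2-carboxyphenyl would add to the response or take from it, since the chloro effect is known only with 4-carboxyphenyl. Also open, from the compounds shown here alone, are whether a tetrazole or a primary amide could stand in for the carboxylic acid on the 2-carboxyphenyl arrangement, and whether a shorter or longer chain would keep the response seen with compound 3.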